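The compounds below may be only part of what the source reports. "The series", "measured", "known", "first", "only" and "open" are said of these compounds alone.

Measured compounds:
- compound 1 `Cc1noc(C)c1-c1cnc(N)c(Oc2ccc(C(=O)NC3CC3)cc2)n1`: 17800 nM
- compound 2 `Cc1noc(C)c1-c1cnc(N)c(Oc2ccc(C(=O)NC3CCCCC3)cc2)n1`: 26100 nM

In a functional assay on HeLa cells (Homo sapiens) for inhibition, read by MTT assay, with a stated time of 72 h (a higher number here means a weaker inhibitor, a lower number a stronger inhibitor), compound 2 gives 26100 nM and sits at the highest of the two numbers; its nearest neighbour is compound 1, and the step of a 1.5-fold higher number from compound 1 to compound 2 (0.17 log units; within the scatter) lies within the scatter, so the two cannot be ordered.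

Compound 3 `Cc1noc(C)c1-c1cnc(N)c(Oc2ccc(C(=O)Nc3ccc(Cl)cc3)cc2)n1` is not yet measured. It differs from compound 2 by 4-chlorophenyl in place of cyclohexyl on an amide-type nitrogen. Among the measured compounds shown here, the only step that bears on the amide nitrogen is a 1.5-fold higher number from compound 1 to compound 2 (0.17 log units; within the scatter), which was within the scatter, and no measured pair exchanges a non-aromatic ring for an aromatic one at that position, so there is nothing in the numbers to point in either direction. The expectation for compound 3 in this assay is therefore a step of a 1.3-fold lower number from compound 2 to compound 3 (0.12 log units; within the scatter), not beyond the scatter. Compound 3 is estimated at 20000 nM, with a range from 5000 nM to 80000 nM.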

Compound 3, half-maximal inhibitory concentration: 2230 nM
Compound 3: the middle estimate sits 9.0-fold (0.95 log units) above what was measured; measured number outside the range, below it.
By their numbers in this assay, from the lowest: compound 3; then compounds 1 and 2 (each within the scatter of the next).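

In this assay the amide nitrogen proves able to move the number: there is a 12-fold lower number from compound 2 to compound 3 (1.07 log units; beyond the scatter) and an 8.0-fold lower number from compound 1 to compound 3 (0.90 log units; beyond the scatter) while the two non-aromatic rings, cyclopropyl and cyclohexyl, could not be ordered. The 4-chlorophenyl group therefore stands apart from both non-aromatic rings, and the step is not tied to one comparator. Nothing available here accounts for this step.

The change from cyclohexyl to 4-chlorophenyl brings in an aromatic ring and a chlorine together, so the compounds shown do not separate the two, and an unsubstituted phenyl on the amide-type nitrogen would be needed to do so. Also open, as far as these compounds go, is how far the step carries over to other groups at this nitrogen, such as benzyl or 4-methoxyphenyl.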